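A few compounds are considered here, and "the series" means these few. Any claim that something is new, unique, unknown or untested is made for them only; others in the source may bear on it.

Measured compounds in a functional assay on HCT-116 cells (Homo sapiens) for cytotoxicity, read by MTT assay, with a stated time of 48 h; on this read-out higher numbers stand for weaker inhibition and lower numbers for stronger inhibition:
compound 1 `O=C(/C=C/c1ccc2c(c1)B(O)OC2)c1ccccc1` gives 6100 nM
compound 2 `Nc1ccc(C(=O)/C=C/c2ccc3c(c2)B(O)OC3)cc1` gives 26100 nM
compound 3 `O=C(/C=C/c1ccc2c(c1)B(O)OC2)c1ccccc1F` gives 4200 nM

Within these three numbers compound 3 has the lowest, though its nearest neighbour is compound 1, and the step of a 1.5-fold lower number from compound 1 to compound 3 (0.16 log units; within the scatter) lies within the scatter, so compound 3 and compound 1 cannot be ranked against each other. Only compound 2 is clearly set apart: the step of a 6.2-fold lower number from compound 2 to compound 3 (0.79 log units; beyond the scatter) is beyond the scatter, as is a 4.3-fold higher number from compound 1 to compound 2 (0.63 log units; beyond the scatter).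

Compound 4 `COc1ccccc1C(=O)/C=C/c1ccc2c(c1)B(O)OC2` is the next member and has not yet been tested in this assay. It differs from compound 3 by methoxy in place of fluoro on an aromatic carbon. Going by the values given here, the one measured step that bears on the same ring is a 1.5-fold lower number from compound 1 to compound 3 (0.16 log units; within the scatter), a change at the same aromatic carbon that stayed within the scatter. The only substitution that moved the number beyond the scatter, a 4.3-fold higher number from compound 1 to compound 2 (0.63 log units; beyond the scatter), put a different group on a different carbon of that ring and sits further from the present change. Two small groups at this carbon having given numbers within the scatter of each other, a methoxy there is expected to produce at most a small step, a 1.2-fold higher number from compound 3 to compound 4 (0.08 log units; within the scatter), with no clear direction.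

Compound 4 is therefore estimated at 5000 nM, with a range of 2000 nM to 15000 nM.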

Compound 4, half-maximal inhibitory concentration: 5000 nM
The estimate for compound 4 equals the measured number at the digits printed, and the stated range covers the measured number.
By their numbers in this assay, from the lowest: compounds 3, 4 and 1 (each within the scatter of the next); then compound 2.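

In this assay, the aromatic carbon ortho to a large group has now carried hydrogen, fluoro and methoxy, and neither step to methoxy leaves the scatter (a 1.2-fold higher number from compound 3 to compound 4 (0.08 log units; within the scatter); a 1.2-fold lower number from compound 1 to compound 4 (0.09 log units; within the scatter)). Methoxy brings two heavy atoms and one hydrogen-bond acceptor in place of the one heavy atom and no acceptor of fluoro, so a change in these counts at this carbon has, in this small set, left the cytotoxicity read-out within the scatter. No supporting measurement accompanies this result, so the flat read-out at this carbon stands as an observation without an explanation.

It remains open whether this flat read-out extends to a carboxylic acid, a primary amine or a longer alkoxy chain at the same carbon, since fluoro and methoxy are the only groups shown there. Going by these compounds alone, the one step beyond the scatter on this ring (a 4.3-fold higher number from compound 1 to compound 2 (0.63 log units; beyond the scatter)) places amino on a different carbon, so it remains open whether that carbon responds to methoxy or fluoro as well, and whether amino would give a similar step at the carbon studied here.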